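The compounds below may be only part of what the source reports. "The series", "measured", "known", "first", "only" and "open" are said of these compounds alone.

Measured in an ADME assay on A549 cells (Homo sapiens) for cytotoxicity, read by resazurin assay, with a stated time of 48 h; on this read-out lower numbers stand for higher toxicity in this test and higher numbers for lower toxicity in this test:
- compound 1 `CC(C)Nc1ccc(NC(=O)c2cc(Cl)ccc2O)c(Cl)c1`: 11000 nM
- compound 2 `CCCN(CCC)c1ccc(NC(=O)c2cc(Cl)ccc2O)c(Cl)c1`: 10700 nM
- compound 3 `O=C(Nc1ccc(NCc2cccc(Br)n2)cc1Cl)c1cc(Cl)ccc1O`: 92300 nM

Of these three, compound 3 gives the highest number, 92300 nM, so it is the least toxic in this assay. Compound 4 `CC(CCO)Nc1ccc(NC(=O)c2cc(Cl)ccc2O)c(Cl)c1` has not yet been measured. Its difference from compound 3 is 3-hydroxy-1-methylpropyl in place of (6-bromopyridin-2-yl)methyl on a nitrogen on an aromatic ring. In short, 3-hydroxy-1-methylpropyl stands in place of (6-bromopyridin-2-yl)methyl on a nitrogen on an aromatic ring.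

Going by the values given here, two measured steps bear directly on this change, since each brings in the group that compound 4 gives up. They are an 8.4-fold higher number from compound 1 to compound 3 (0.92 log units; beyond the scatter) and an 8.6-fold higher number from compound 2 to compound 3 (0.94 log units; beyond the scatter), and the two are almost the same size. Among the groups without a ring, a 1.0-fold lower number from compound 1 to compound 2 (0.01 log units; within the scatter) shows that swapping one for another made no real difference. The new group also has no ring, so a return towards the lower numbers seems likely, and compound 1 at 11000 nM is the nearest guide. Among the compounds with values here, no measured compound here carries a hydroxy group, however, so the full return is uncertain.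

The expected change is a 5.4-fold lower number from compound 3 to compound 4 (0.73 log units; beyond the scatter), a clear drop but probably a somewhat smaller one than those measured steps. The estimate for compound 4 is 17000 nM, with an expected range of 7000 nM to 45000 nM.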

Compound 4, half-maximal cytotoxic concentration: 200000 nM
Beside the measured number, compound 4's estimate is 12-fold (1.07 log units) below it; the whole stated range lies below it.
By their numbers in this assay, from the lowest: compounds 2 and 1 (each within the scatter of the next); then compound 3; then compound 4.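

In this assay, the pyridine ring of the (6-bromopyridin-2-yl)methyl group is not needed for a high number on this nitrogen, since the ring-free 3-hydroxy-1-methylpropyl group gives a 2.2-fold higher number from compound 3 to compound 4 (0.34 log units; beyond the scatter) and compound 4 now stands highest of the four. The earlier ring-free groups had stayed together at the low end, but this one breaks from them: hydroxymethyl in place of hydrogen on a saturated chain carbon gives an 18-fold higher number from compound 1 to compound 4 (1.26 log units; beyond the scatter), and replacing dipropylamino with (3-hydroxy-1-methylpropyl)amino gives a 19-fold higher number from compound 2 to compound 4 (1.27 log units; beyond the scatter), so a change on the chain alone can move this read-out further than the ring-bearing group did. Nothing measured here explains why this small change has so large an effect.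

The compounds shown do not separate the contribution of the hydroxy group from that of the longer chain, which a plain butan-2-yl group on the same nitrogen would help to settle. A methyl ether, an amine or a carboxylic acid at the chain end would show whether the terminal hydroxy group can be replaced without losing the high number.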